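Moving the Chlorine Along the Benzyl Ring

A few compounds are considered here, and "the series" means these few. Any claim that something is new, unique, unknown or untested is made for them only; others in the source may bear on it.

Measured compounds:
Compound 1 `COc1ccc(C2N=C(SCc3ccccc3)NC(C)=C2C(=O)Nc2ccc(Br)cc2)cc1`: 18.6%
Compound 2 `COc1ccc(C2N=C(SCc3ccccc3Cl)NC(C)=C2C(=O)Nc2ccc(Br)cc2)cc1`: 20.6%

Both compounds were tested in a functional assay on the whole organism (artery, strain albino) with Rattus norvegicus as the target, with a stated time of 360 min, at a dose of 10 mg/kg by the oral route; on this read-out lower numbers stand for less inhibition and higher numbers for more inhibition at the one dose given (going by the name of the read-out). Among the compounds with values here, compound 1 and compound 2 share one core and differ only in a chloro in place of hydrogen on an aromatic carbon; the step of a number 2 percentage points higher from compound 1 to compound 2 (within the scatter) lies within the scatter, so the two cannot be told apart on this read-out, and compound 2 stands level with its only neighbour.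

Compound 3 `COc1ccc(C2N=C(SCc3cccc(Cl)c3)NC(C)=C2C(=O)Nc2ccc(Br)cc2)cc1` is not yet measured. It differs from compound 2 by 3-chlorophenyl in place of 2-chlorophenyl on a saturated chain carbon bound to a sulfur. Within the data shown here, the only step seen so far, a number 2 percentage points higher from compound 1 to compound 2 (within the scatter), concerns adding a chlorine to this benzyl ring, not moving it, and that step stayed within the scatter. Among the measured compounds shown here, no measured pair shows what shifting the chlorine along the ring does. With nothing pointing either way, the expected step of a number 0.6 percentage points lower from compound 2 to compound 3 (within the scatter) is none beyond the scatter. Compound 3 is therefore estimated to give 20% in this assay, in a range from 8% to 32%.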

Compound 3, a percentage reported as inhibition, in the whole organism at one dose (the size of the read-out at that dose, not a potency): 39.7%
Compound 3: middle estimate off by 19.7 percentage points, on the low side; measured number above the stated range.
By their numbers in this assay, from the lowest: compounds 1 and 2 (each within the scatter of the next); then compound 3.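

Where the chlorine sits on the benzyl ring matters in this assay, a point that adding the chlorine in one place could not show. Within the data shown here, with the same atoms joined differently, the change from 2-chlorobenzyl to 3-chlorobenzyl on the sulfur gives a number 19.1 percentage points higher from compound 2 to compound 3 (beyond the scatter) and is the first change in this small set to stand clear of the usual scatter. Adding a chlorine to the plain benzyl group therefore has no single outcome, as the 2-chlorophenyl group gives a number 2 percentage points higher from compound 1 to compound 2 (within the scatter) while the 3-chlorophenyl group gives a number 21.1 percentage points higher from compound 1 to compound 3 (beyond the scatter) and the effect depends on the place of the chlorine; no measurement at hand bears on why this is so.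

The compounds shown leave open whether this rise belongs to chlorine itself or would also appear with a fluorine or a methyl group on the ring in its place. They also leave open whether it survives a longer chain between the sulfur and the ring, and whether the order of the compounds would hold at other doses or times.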